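The compounds below may be only part of what the source reports. "The series", "measured", "known", "first", "only" and "open" are said of these compounds alone.

Measured compounds:
compound 1, `CCCCC(Sc1nc(Cl)cc(Nc2ccc3ncccc3c2)n1)C(=O)OCC`, 51.8% in an assay for inhibition of Polyunsaturated fatty acid 5-lipoxygenase (Homo sapiens), tested at 1 uM; a lower number here means a stronger effect, a higher number a weaker effect of the compound at the concentration tested
compound 2, `CCCCC(Sc1nc(Cl)cc(Nc2ccc3ncccc3c2)n1)C(=O)O`, "not active" (no number reported) in this assay

In this assay compound 1 gives 51.8%. Going by the values given here, compound 2 is reported in this assay only as "not active" (no number reported), with no number attached, so compound 2 stands without a place on the numerical scale, and the size of the gap between compound 1 and compound 2 cannot be stated; the two results show only that compound 1 returns a number and compound 2 does not.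

Compound 3, `O=C(O)C(Sc1nc(Cl)cc(Nc2ccc3ncccc3c2)n1)c1ccccc1`, has not yet been measured in this assay. It differs from compound 2 in one place: phenyl in place of butyl on a saturated chain carbon bound to a carbonyl carbon and a sulfur. Among the compounds with values here, since no step between measured compounds is known, there is no measured basis for expecting the change to pull compound 3 toward a stronger effect in this assay; the expectation is for no step beyond the scatter, with compound 3 staying at the weak end where compound 2 is reported. For compound 3 in this assay the estimate is 90%, expected within a range from 65% to 100%, with a fair chance that it too is reported only as not active.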

Compound 3, a percentage reported as activity, at one concentration (the size of the read-out at that concentration, not a potency): "not active" (no number reported)
Compound 3: no number reported, and the estimate cannot be compared.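

Going by these compounds alone, compound 3, like compound 2, is reported in this assay only as not active, with no number attached, so no step between the two can be read. No evidence at hand bears on this result. The compounds shown leave open whether phenyl in place of butyl changes the effect in this assay at all.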